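The compounds below may be only part of what the source reports. "The series", "measured", "known", "first", "only" and "open" are said of these compounds alone.

Measured in a functional assay on MDA-MB-231 cells (Homo sapiens) for inhibition, read by CellTiter-Glo, with a stated time of 72 h; on this read-out lower numbers stand for higher toxicity in this test and higher numbers for lower toxicity in this test:
- compound 1 `CC1=C(CC(=O)NCCN(C)C)c2cc(F)ccc2/C1=C\c1nc2ccccc2s1` gives 3630 nM
- compound 2 `CC1=C(CC(=O)NCCN(C)C)c2cc(F)ccc2/C1=C\c1ccncc1` gives 18100 nM
- compound 3 `CC1=C(CC(=O)N2CCN(c3ccncc3)CC2)c2cc(F)ccc2/C1=C\c1ccc([S+](C)[O-])cc1` gives 22700 nM

Compound 1 holds the lowest number of the three. Compound 4 `CC1=C(CC(=O)N2CCN(CCCN(C)C)CC2)c2cc(F)ccc2/C1=C\c1nc2ccccc2s1` is still unmeasured and departs from compound 1 on a carbonyl carbon: 4-(3-(dimethylamino)propyl)piperazin-1-yl in place of (2-(dimethylamino)ethyl)amino on a carbonyl carbon. For the measured compounds named here, the only measured step, a 5.0-fold higher number from compound 1 to compound 2 (0.70 log units; beyond the scatter), lies at the double-bonded chain carbon and not at the carbonyl carbon, so it offers no more than a scale for the series. Compound 3 also carries a ring on the carbonyl carbon and stands at 22700 nM, but it differs from compound 1 elsewhere too, so that value cannot be credited to the ring alone. Going by the values given here, no measured step covers a change at this place and no direction is supported. A shift no larger than the modest measured step is expected in this assay, most likely none beyond the scatter. The expected step is a 1.2-fold lower number from compound 1 to compound 4 (0.08 log units; within the scatter). For compound 4 the estimated value is 3000 nM, with an expected range of 1000 nM to 9000 nM.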

Compound 4, half-maximal cytotoxic concentration: 2900 nM
The estimate for compound 4 lay 1.0-fold (0.01 log units) above the measured number; the range from low to high includes it.
By their numbers in this assay, from the lowest: compounds 4 and 1 (each within the scatter of the next); then compounds 2 and 3 (each within the scatter of the next).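

In this assay, the carbonyl carbon accepts a large change of group without a shift beyond the scatter: a 1.3-fold lower number from compound 1 to compound 4 (0.10 log units; within the scatter) when 4-(3-(dimethylamino)propyl)piperazin-1-yl replaces (2-(dimethylamino)ethyl)amino. For the compounds shown here, with 1,3-benzothiazol-2-yl held constant, this pair gives the first clean reading at this place, and for this pair the loss of the amide hydrogen and the gain of a six-membered non-aromatic ring leave the number unchanged within the scatter. No measurement is available to explain why the two groups read alike.

From the compounds shown here alone, compound 1 and compound 4 both carry a dimethylamino group, so the effect of a morpholine or a carboxylic acid on the carbonyl carbon remains open. Also open, going by these compounds, is whether this swap reads the same with pyridin-4-yl on the double-bonded chain carbon, the change that gave a 5.0-fold higher number from compound 1 to compound 2 (0.70 log units; beyond the scatter).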